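Shortening the carbamate chain in a selenocyanate series

This account rests on a few compounds, and the source may have more. Where it says the series, first, only, none or still open, it means among the compounds named here.

Three aryl selenocyanate carbamates have been measured in a functional assay on CCRF-CEM cells (Homo sapiens) for cytotoxicity, read by MTT assay, with a stated time of 72 h; on this read-out higher numbers stand for weaker inhibition of growth and lower numbers for stronger inhibition of growth. Compound 1 `CCCOC(=O)Nc1ccc([Se]C#N)cc1` gives 9300 nM, and compound 2 `CC(C)COC(=O)Nc1ccc([Se]C#N)cc1` gives 9300 nM. Compound 3 `CCCCCCOC(=O)Nc1ccc([Se]C#N)cc1` gives 19700 nM in this assay, the highest of the three numbers; both compound 1 and compound 2 sit lower by the same margin, a 2.1-fold higher number from compound 1 to compound 3 (0.33 log units; beyond the scatter) and a 2.1-fold higher number from compound 2 to compound 3 (0.33 log units; beyond the scatter). Between compound 1 and compound 2 there is no change at the digits printed from compound 1 to compound 2 (within the scatter).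

Compound 4 `CCOC(=O)Nc1ccc([Se]C#N)cc1` has not yet been measured in this assay. It differs from compound 3 by hydrogen in place of butyl on a saturated chain carbon, two bonds along the chain from an oxygen next to a carbonyl group, so the chain on the carbamate oxygen is cut back to ethyl, shorter even than the propyl of compound 1. Among the measured compounds shown here, the steps that bear on this are the two that lengthen the chain, a 2.1-fold higher number from compound 1 to compound 3 (0.33 log units; beyond the scatter) and a 2.1-fold higher number from compound 2 to compound 3 (0.33 log units; beyond the scatter), both modest and both in the direction of a higher number as the chain grows. Reversing that trend, a modest step to a lower number is expected from compound 3 to compound 4, roughly a 2.5-fold lower number from compound 3 to compound 4 (0.39 log units; beyond the scatter), with compound 4 landing near compound 1 or somewhat below it. Compound 4 is therefore estimated at 8000 nM in this assay, with a range of 4000 nM to 16000 nM.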

Compound 4, concentration for 50% growth inhibition: 9800 nM
Estimate against measurement, compound 4: 1.2-fold (0.09 log units) below; measured number inside the range.
By their numbers in this assay, from the lowest: compounds 1, 2, 4 and 3 (each within the scatter of the next, the first and the last beyond it).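

In this assay the ethyl chain of compound 4 falls in with the two shorter chains measured before it: the readings a 1.1-fold higher number from compound 1 to compound 4 (0.02 log units; within the scatter) and a 1.1-fold higher number from compound 2 to compound 4 (0.02 log units; within the scatter) show that cutting the chain back past that of compound 1 brings no difference that can be told from the scatter. The full cut from hexyl to ethyl gives a 2.0-fold lower number from compound 3 to compound 4 (0.30 log units; within the scatter) and so does not set these two compounds apart, whereas compound 1 and compound 2 each remain just beyond the scatter from compound 3, which means the link between chain length and the read-out across these compounds is slight and does not hold for every pair. Nothing at hand explains this flat stretch among the shorter chains.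

The compounds shown leave open whether a chain longer than hexyl would move the number clearly away from the others, and whether methyl on the carbamate oxygen would stay with the short chains. They also leave open what an amine or a carboxylic acid carried on this chain would do to growth inhibition in these cells.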